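This account rests on a few compounds, and the source may have more. Where it says the series, first, only, none or still open, it means among the compounds named here.

Compound 1 `Cn1ncc(Cl)c1-c1cc(C(=O)N[C@@H]2CN[C@H](CCO)C[C@H]2c2ccc(F)c(F)c2)oc1Cl` gives 60 nM in a functional assay on LNCaP cells (Homo sapiens) for antiproliferative activity; a lower number here means a stronger inhibitor, a higher number a weaker inhibitor. Its ester analogue compound 2 `CC(=O)OCC[C@@H]1C[C@@H](c2ccc(F)c(F)c2)[C@H](NC(=O)c2cc(-c3c(Cl)cnn3C)c(Cl)o2)CN1` returns "not determined" (no result reported) in this assay. Compound 3 `CNC(=O)C[C@@H]1C[C@@H](c2ccc(F)c(F)c2)[C@H](NC(=O)c2cc(-c3c(Cl)cnn3C)c(Cl)o2)CN1` gives 50 nM in this assay, which is the lowest of the two numbers recorded; the nearest is compound 1, and the step of a 1.2-fold lower number from compound 1 to compound 3 (0.08 log units; within the scatter) lies within the scatter. Compound 4 `Cn1ncc(Cl)c1-c1cc(C(=O)N[C@@H]2CN[C@H](CCNS(C)(=O)=O)C[C@H]2c2ccc(F)c(F)c2)oc1Cl` differs from compound 3 in one place: (methanesulfonamido)methyl in place of methylcarbamoyl on a saturated chain carbon bound to a saturated ring carbon. Among the measured compounds shown here, only the step from compound 1 to compound 3 bears on this change, and it was within the scatter, so no shift beyond the scatter is expected; the step from compound 3 to compound 4 is estimated as a 1.1-fold higher number from compound 3 to compound 4 (0.04 log units; within the scatter). Compound 4 is therefore expected to give about 55 nM, between 25 nM and 120 nM.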

Compound 4, half-maximal inhibitory concentration: 50 nM
Compound 4: middle estimate off by 1.1-fold (0.04 log units), on the high side, and the stated range covers the measured number.
By their numbers in this assay, from the lowest: compounds 3, 4 and 1 (each within the scatter of the next).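

In this assay, the methanesulfonamide-bearing chain of compound 4 leaves the number in place: (methanesulfonamido)methyl for methylcarbamoyl gives no change at the digits printed from compound 3 to compound 4 (within the scatter), and methanesulfonamido for hydroxy gives a 1.2-fold lower number from compound 1 to compound 4 (0.08 log units; within the scatter). On this saturated chain carbon bound to a saturated ring carbon, hydroxy, methylcarbamoyl and methanesulfonamido chain ends thus all lie within the scatter of one another. Nothing available accounts for this. Going by these compounds, it remains open whether an amine or a carboxylic acid at the chain end, or a longer chain, would keep the number there.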